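This account rests on a few compounds, and the source may have more. Where it says the series, first, only, none or still open, it means among the compounds named here.

Measured so far in a functional assay on K562 cells (Homo sapiens), read by MTT assay, with a stated time of 72 h; a lower number here means a stronger inhibitor, a higher number a weaker inhibitor:
Compound 1 `COc1ncnc2c1c(-c1cccs1)cn2[C@@H]1O[C@H](CO)[C@@H](O)[C@H]1O` gives 70 nM in this assay.
Compound 2 `COc1ncnc2c1c(-c1ccccc1)cn2[C@@H]1O[C@H](CO)[C@@H](O)[C@H]1O` reaches only the limit > 20000 nM in this assay.
Compound 3 `CNc1ncnc2c1c(-c1ccoc1)cn2[C@@H]1O[C@H](CO)[C@@H](O)[C@H]1O` reaches only the limit > 20000 nM in this assay.

Compound 3 thus stands at the limit of this assay, not at a number; the same limit holds for compound 2, so that (the limit of > 20000 nM in this assay, at which 2 of the 3 values shown sit). Among the measured compounds shown here, only one step has been measured: an at least 280-fold higher number from compound 1 to compound 2 (2.45 log units; beyond the scatter). That step changes the aryl group on the shared core, not the group at the position changed here, and so does not bear directly on compound 4.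

Compound 4 `COc1ncnc2c1c(-c1ccoc1)cn2[C@@H]1O[C@H](CO)[C@@H](O)[C@H]1O` differs from compound 3 by methoxy in place of methylamino on an aromatic carbon. For the measured compounds named here, no measured step describes this exchange, and because compound 3 sits at a limit, the size and direction of the step to compound 4 in this assay cannot be read from the data. The furan-3-yl group of compound 4 is also not present in compound 1 or compound 2, so their values give no direct guide. Compound 4 is therefore expected to give about 5000 nM, in the range 300 nM to 20000 nM, with a fair chance that this assay again reports only a limit. The expected step is an at least 4.0-fold lower number from compound 3 to compound 4 (0.60 log units; beyond the scatter).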

Compound 4, half-maximal inhibitory concentration: 190 nM
For compound 4 the middle estimate is 26-fold (1.42 log units) above the measured one, and the stated range ends above it.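

With furan-3-yl held fixed in this assay, the exchange of methylamino for methoxy on this aromatic carbon next to the ring nitrogen decides whether a number can be read at all: an at least 100-fold lower number from compound 3 to compound 4 (2.02 log units; beyond the scatter). With methoxy held fixed, the aryl exchanges show that furan-3-yl stands far from phenyl, an at least 100-fold lower number from compound 2 to compound 4 (2.02 log units; beyond the scatter), but much closer to thiophen-2-yl, a 2.7-fold higher number from compound 1 to compound 4 (0.43 log units; beyond the scatter). The first two of these steps start from a limit and give only a bound on their size: the limit of > 20000 nM in this assay, at which 2 of the 4 values shown sit.

The compounds shown leave open how far the methylamino effect carries over to thiophen-2-yl, or to any aryl group other than furan-3-yl. They also leave open whether a larger or different group at this position, such as ethoxy, dimethylamino or a plain amine, would keep a value close to that of methoxy.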